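Amide aryl variation on a shared core: adding a methyl

This account rests on a few compounds, and the source may have more. Where it says the series, first, only, none or still open, it means among the compounds named here.

Measured compounds, all in a functional assay on AN3-CA cells (Homo sapiens) for antiproliferative activity, read by MTT assay, with a stated time of 72 h; on this read-out higher numbers stand for weaker inhibition and lower numbers for stronger inhibition:
compound 1 `O=C(Nc1ccc(Cl)c(-c2nnc3c(Cl)cccn23)c1)c1ccccc1` gives 67600 nM
compound 2 `Cc1nc(C(=O)Nc2ccc(Cl)c(-c3nnc4c(Cl)cccn34)c2)cs1` gives > 100000 nM, a limit of the assay and not a number
compound 3 `O=C(Nc1ccc(Cl)c(-c2nnc3c(Cl)cccn23)c1)c1ccc(Cl)cc1` gives > 100000 nM, likewise a limit of the assay and not a number

Compound 3 therefore stands at the limit in this assay, together with one other value: the limit of > 100000 nM in this assay, at which 2 of the 3 values shown sit. From compound 1 the two recorded changes read an at least 1.4-fold higher number from compound 1 to compound 2 (0.17 log units; that floor lies within the scatter) and an at least 1.4-fold higher number from compound 1 to compound 3 (0.17 log units; that floor lies within the scatter); the change between the two limits is a step that the two limits leave unreadable from compound 2 to compound 3.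

Compound 4 `Cc1cc(Cl)ccc1C(=O)Nc1ccc(Cl)c(-c2nnc3c(Cl)cccn23)c1` carries the next variation on the amide aryl group: methyl in place of hydrogen on an aromatic carbon. Cut one bond further out, this reads 4-chlorophenyl to 4-chloro-2-methylphenyl. Among the compounds with values here, no measured step joins a hydrogen-to-methyl exchange on that ring, so the only guidance is that compound 3 sits at the limit, and the one change that leads to compound 3 (an at least 1.4-fold higher number from compound 1 to compound 3 (0.17 log units; that floor lies within the scatter)) has a floor that lies within the scatter.

The expectation for compound 4 in this assay is that the value stays at or near the limit, with the expected step being a number no higher from compound 3 to compound 4 (the limit leaves the size open), that is, none readable beyond the scatter. The estimated value for compound 4 is 100000 nM, with an expected range from 40000 nM to 250000 nM.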

Compound 4, half-maximal inhibitory concentration: > 100000 nM
Compound 4 ended at the assay's limit (the forecaster's own chance of this, stated with the estimate: 70%); the middle value lies on the limit itself.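

In this assay compound 4 gives > 100000 nM, a limit of the assay and not a number, so this hydrogen-to-methyl exchange on an aromatic carbon ortho to a large group yields no value that can be placed against the 4-chlorophenyl amide. Within the data shown here, the only step with a readable floor is an at least 1.4-fold higher number from compound 1 to compound 4 (0.17 log units; that floor lies within the scatter); the steps among the compounds at the limit cannot be read, so the methyl may have no effect or an effect of either direction that stays hidden. What this adds to the earlier compounds is a third amide aryl group at the same ceiling, now one with two ring substituents: the limit of > 100000 nM in this assay, at which 3 of the 4 values shown sit.

Among these compounds, compound 1 remains the only compound here with a true number, and its unsubstituted phenyl is the sole reference for any change on this ring, so a methyl on that phenyl without the chloro group remains an open comparison. Also open, going by these compounds, is whether an amine or a carboxylic acid on the amide aryl ring would give a value that falls clearly below that of compound 1 in this assay.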